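Hydroxyalkyl change in a series sitting at its limit

The source may report more compounds than this note shows. Statements on the series, on what has been measured and on what is new or still open speak of the compounds shown alone.

Compound 3 (`COc1cc(NC(C)CCCNC(=O)NNC(=O)N(CCO)CCO)c2ncccc2c1`) gives > 250000 nM in a functional assay on MIA PaCa-2 cells (Homo sapiens) for inhibition, read by MTT assay, with a stated time of 4 days (on this read-out lower numbers stand for stronger inhibition and higher numbers for weaker inhibition), as a limit and not a number. Compound 1 (`COc1cc(NC(C)CCCNC(=O)NNC(=O)NCCO)c2ncccc2c1`) gives >= 250000 nM in this assay as a limit too. Compound 2 (`COc1cc(NC(C)CCCNC(=O)NNC(=O)NC(CO)(CO)CO)c2ncccc2c1`) gives > 250000 nM in this assay as a limit as well. All three measured compounds therefore sit at a limit, and none goes against that pattern.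

Compound 4 (`COc1cc(NC(C)CCCNC(=O)NNC(=O)NCCCO)c2ncccc2c1`) carries (3-hydroxypropyl)amino in place of bis(2-hydroxyethyl)amino on a carbonyl carbon.

Within the data shown here, three measured steps bear on this change: (a step that the two limits leave unreadable from compound 1 to compound 3), (a step that the two limits leave unreadable from compound 1 to compound 2) and (a step that the two limits leave unreadable from compound 2 to compound 3). None of them has a readable size, so no size carries over, and the expectation rests only on all three compounds staying at the limit.

The expected outcome is a number no higher from compound 3 to compound 4 (the limit leaves the size open) in this assay, with no direction and nothing beyond the scatter. For compound 4 the estimate is 250000 nM with an expected range from 100000 nM to 500000 nM and a limit is the likeliest result.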

Compound 4, half-maximal inhibitory concentration: >= 250000 nM
Compound 4: only a limit was reported (the forecaster's own chance of this, stated with the estimate: 85%); the middle value sits exactly at the limit.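

In this assay compound 4 gives >= 250000 nM, a limit and not a number. Its steps from compound 1, compound 2 and compound 3 therefore cannot be read. The compounds shown leave open whether any of these hydroxyalkyl changes alters inhibition at all.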